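The compounds below may be only part of what the source reports. "The series", "measured", "known", "first", "only" and "open" are said of these compounds alone.

Measured compounds:
compound 1 `CCCn1c(=O)[nH]c2nc(-c3ccc(S(=O)(=O)N4CCN(c5ccc(Cl)cc5F)CC4)cc3)[nH]c2c1=O` — in an assay on CHO cells for displacement of a labelled ligand from adenosine receptor A2b (Homo sapiens), read by scintillation counting, with a stated time of 75 min, in the presence of a further agent that is not named here (on this read-out higher numbers stand for weaker inhibition and lower numbers for stronger inhibition), compound 1 gives 1.91 nM
compound 2 `CCCn1c(=O)[nH]c2nc(-c3ccc(S(=O)(=O)N4CCN(c5ccccc5)CC4)cc3)[nH]c2c1=O` — in this assay compound 2 gives 0.643 nM

Within the data shown here, compound 2 holds the lowest of the two numbers in this assay; its nearest neighbour is compound 1, and the only step in the set is a 3.0-fold lower number from compound 1 to compound 2 (0.47 log units; beyond the scatter), a modest move that lies beyond the scatter. Compound 3 `CCCn1c(=O)[nH]c2nc(-c3ccc(S(=O)(=O)N4CCN(Cc5ccc(Br)cc5)CC4)cc3)[nH]c2c1=O` alters the same site: 4-bromobenzyl in place of phenyl on an amine nitrogen in a ring. Among the measured compounds shown here, that step has no direct precedent; the one measured step touches the same ring amine nitrogen, but it exchanged one aryl group for another, whereas here a benzyl group with a bromine enters. Compound 1, the only other substituent bearing halogens at this position, returned the higher number, so a modest rise from compound 2 is expected rather than a further fall, with wide uncertainty. For compound 3 the estimate in this assay is 2 nM, in the range 0.5 nM to 8 nM. This corresponds to an expected step of a 3.1-fold higher number from compound 2 to compound 3 (0.49 log units; beyond the scatter).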

Compound 3, inhibition constant: 0.153 nM
For compound 3 the middle estimate is 13-fold (1.12 log units) above the measured one; measured number outside the range, below it.
By their numbers in this assay, from the lowest: compound 3; then compound 2; then compound 1.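

In this assay, the ring amine nitrogen accepts a benzyl group as well as a directly attached aryl group: 4-bromobenzyl in place of phenyl gives a 4.2-fold lower number from compound 2 to compound 3 (0.62 log units; beyond the scatter), and in place of 4-chloro-2-fluorophenyl it gives a 12-fold lower number from compound 1 to compound 3 (1.10 log units; beyond the scatter). Halogen on the substituent therefore does not go with a higher number across this set: compound 1 fits that reading, and compound 3 goes against it. No measurement in hand accounts for either step.

As far as these compounds go, how the step divides between the bromine and the methylene link stays open; a plain benzyl or a 4-bromophenyl group on this nitrogen would separate the two. Also open, from the compounds shown here alone, is whether a longer chain such as 2-phenylethyl, or a carboxylic acid on the benzyl ring, would keep the number this low.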